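Benzyl on the amide nitrogen: compound 3 to compound 4

The source may report more compounds than this note shows. Statements on the series, on what has been measured and on what is new or still open speak of the compounds shown alone.

In a functional assay on HEY cells (Homo sapiens) for cytotoxicity, read by MTT assay, with a stated time of 72 h (on this read-out higher numbers stand for weaker inhibition and lower numbers for stronger inhibition), compound 1 (`N[C@H]1CC[C@H](Nc2c(C(=O)NCc3ccc(Oc4ccccc4)cc3)nc(Br)c3cccnc23)CC1`) gives 9000 nM and compound 2 (`N[C@H]1CC[C@H](NC(=O)c2nc(Br)c3cccnc3c2NCc2ccc(F)cc2)CC1`) gives 7100 nM, two values within the usual scatter of each other. In this assay compound 3 (`C[C@H](NC(=O)c1nc(Br)c2cccnc2c1N[C@H]1CC[C@H](N)CC1)c1ccc(F)cc1`) gives > 10000 nM, which is a limit of the assay and not a number. Compound 3 therefore stands at the limit of > 10000 nM in this assay, at which 1 of the 3 values shown sits.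

Compound 4 (`N[C@H]1CC[C@H](Nc2c(C(=O)NCc3ccccc3)nc(Br)c3cccnc23)CC1`), not yet measured, has benzyl in place of 1-(4-fluorophenyl)ethyl on an amide-type nitrogen. The change also removes the defined stereocentre of the leaving group.

Within the data shown here, no measured step gives a size for this change. In this assay only a small shift towards stronger inhibition, not beyond the scatter, is expected, and the expected step is an at least 1.1-fold lower number from compound 3 to compound 4 (0.04 log units; that floor lies within the scatter). This expectation leans on compound 1 at 9000 nM, whose amide-type nitrogen also carries a substituted benzyl group. For compound 4 the estimated value is 9000 nM, with an expected range of 3500 nM to 20000 nM.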

Compound 4, half-maximal inhibitory concentration: 8000 nM
For compound 4 the middle estimate is 1.1-fold (0.05 log units) above the measured one, and the stated range covers the measured number.
By their numbers in this assay, from the lowest: compounds 2, 4 and 1 (each within the scatter of the next). At a limit, above all of these: compound 3.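

In this assay, benzyl in place of 1-(4-fluorophenyl)ethyl on an amide-type nitrogen gives an at least 1.2-fold lower number from compound 3 to compound 4 (0.09 log units; that floor lies within the scatter), which is a floor and does not fix the size of the change. Compound 3 remains a limit of the assay and not a number: the limit of > 10000 nM in this assay, at which 1 of the 4 values shown sits.

Hydrogen in place of phenoxy on an aromatic carbon gives a 1.1-fold lower number from compound 1 to compound 4 (0.05 log units; within the scatter), so in this assay the plain benzyl amide and its phenoxy-bearing counterpart cannot be told apart.

From the compounds shown here alone, how far compound 3 lies past its limit stays open, and with it the true size of the step to compound 4. Also open, going by these compounds, is whether an amine or a carboxylic acid in place of phenoxy, or a longer chain in place of benzyl, would move the number beyond the scatter.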